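Oxan-4-yl in place of trifluoromethyl in compound 4

A few compounds are considered here, and "the series" means these few. Any claim that something is new, unique, unknown or untested is made for them only; others in the source may bear on it.

In a functional assay on SH-SY5Y cells (Homo sapiens) for antagonist activity, read by cAMP accumulation (a higher number here means a more potent compound, by a factor of ten per unit of this negative logarithm, a lower number a less potent compound), compound 3 `FC(F)(F)COc1ccc(Cc2ccc(NC3=NCCN3)cc2)cc1` reads 8.7 and stands highest of the three measured compounds. Compound 1 `CCOc1ccc(Cc2ccc(NC3=NCCN3)cc2)cc1` gives 8.2 in the same test, and compound 2 `c1ccc(COc2ccc(Cc3ccc(NC4=NCCN4)cc3)cc2)cc1` gives 7.7 there. Compound 4 `c1cc(NC2=NCCN2)ccc1Cc1ccc(OCC2CCOCC2)cc1` has not yet been measured. It carries oxan-4-yl in place of trifluoromethyl on a saturated chain carbon bound to an oxygen on an aromatic ring, a difference that reads oxan-4-yl in place of trifluoromethyl on a saturated chain carbon bound to an oxygen on an aromatic ring when counted out.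

Three measured steps at this same place bear on the change, namely a number 0.50 log units lower from compound 1 to compound 2 (beyond the scatter) with phenyl entering, a number 0.50 log units higher from compound 1 to compound 3 (beyond the scatter) with trifluoromethyl entering and a number 1.00 log units higher from compound 2 to compound 3 (beyond the scatter) with trifluoromethyl replacing phenyl, all of them modest. Among the measured compounds shown here, compound 2 holds the only ring among the measured groups here, and no measured compound has a non-aromatic ring at this place. In this assay the expected move is a number 0.80 log units lower from compound 3 to compound 4 (beyond the scatter) and is estimated as a modest fall. Compound 4 is therefore expected at 7.9 with a range from 7.3 to 8.5 as the estimate.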

Compound 4, negative logarithm of the antagonist equilibrium constant: 8.5
The estimate for compound 4 lay 0.60 log units below the measured number; the measured number falls inside the stated range.
By their numbers in this assay, from the lowest: compound 2; then compounds 1, 4 and 3 (each within the scatter of the next, the first and the last beyond it).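

In this assay, the first non-aromatic ring at this place, oxan-4-yl, cannot be told apart from the smaller groups: the change gives a number 0.20 log units lower from compound 3 to compound 4 (within the scatter) and a number 0.30 log units higher from compound 1 to compound 4 (within the scatter). Against the aromatic ring the same group gives a number 0.80 log units higher from compound 2 to compound 4 (beyond the scatter), so among the listed compounds, the lower reading of compound 2 does not extend to every ring on this saturated chain carbon. No measurement here explains why phenyl and oxan-4-yl differ at this place.

The compounds shown leave open whether the ring oxygen of oxan-4-yl matters, as cyclohexyl, with carbon at that ring position, would test. They also leave open how piperidin-4-yl, a ring amine, or a longer chain carrying the oxan-4-yl ring would read at this place.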